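The source may hold more compounds than are shown below. What is called first, only, known or untested is meant among the compounds shown, and "the series" means these compounds.

Measured compounds and their values:
compound 1, `C=CCn1c(=O)/c(=C\c2cccc(Cl)c2Cl)[nH]c(=O)/c1=C\c1ccccc1OC`: 2300 nM
compound 2, `C=CCn1c(=O)/c(=C\c2ccc(Cl)c(Cl)c2)[nH]c(=O)/c1=C\c1ccccc1OC`: "not active" (no number reported)
compound 3, `C=CCn1c(=O)/c(=C\c2ccccc2OC)[nH]c(=O)/c1=C\c1ccccc1OC`: 22400 nM

Three compounds share one core and differ only in the aromatic group carried on a double-bonded chain carbon. In a functional assay on A549 cells (Homo sapiens) for cytotoxicity, read by CCK-8 assay, with a stated time of 72 h (on this read-out lower numbers stand for stronger inhibition and higher numbers for weaker inhibition), compound 1 gives 2300 nM. Compound 2 is reported as "not active" (no number reported), without a number. Among the measured compounds shown here, compound 3 gives 22400 nM, the higher of the two numbers available, so among the measured compounds it is the weaker inhibitor; the single step of a 9.7-fold higher number from compound 1 to compound 3 (0.99 log units; beyond the scatter) is beyond the scatter.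

Compound 4, `C=CCn1c(=O)/c(=C\c2ccc(C)cc2)[nH]c(=O)/c1=C\c1ccccc1OC`, is not yet measured. It differs from compound 3 by 4-methylphenyl in place of 2-methoxyphenyl on a double-bonded chain carbon bound to an aromatic carbon. For the measured compounds named here, the only measured step at this position, a 9.7-fold higher number from compound 1 to compound 3 (0.99 log units; beyond the scatter), shows that exchanging the aromatic group here can shift the number substantially, and compound 2 shows that another exchange can remove measurable activity altogether. Going by the values given here, no measured pair shows what a 4-methylphenyl group does at this position, so the direction of the step cannot be read from the data. The expectation is therefore a step of a 1.5-fold lower number from compound 3 to compound 4 (0.17 log units; within the scatter), with a wide range on both sides. Compound 4 is estimated at 15000 nM, between 4000 nM and 60000 nM.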

Compound 4, half-maximal inhibitory concentration: "not active" (no number reported)
Compound 4 has no reported number here; the estimate stays without a comparison.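

Among the compounds shown here, compound 4, like compound 2, is reported as "not active" without a number, so no step from compound 3 to compound 4 can be read. Nothing measured here offers an explanation for this result. The compounds shown leave open where compound 2 and compound 4 would stand in numbers beside compound 1 and compound 3.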